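The source may report more compounds than this note shows. Statements on the series, on what has been measured and on what is new or still open speak of the compounds shown alone.

For the measured compounds named here, compound 1 `COc1ccc(-c2cc(=O)c3c(OC)cc(OC)cc3n2C)cc1` holds the only actual number in this set: in an ADME assay on BJ cells (Homo sapiens) for antiproliferative activity, with a stated time of 72 h (on this read-out higher numbers stand for an effect only at larger amounts of compound and lower numbers for an effect already at smaller amounts), compound 1 gives 68000 nM. Compound 2 `COc1ccc(-c2cc(=O)c3c(OC)cc(OC)cc3n2S(=O)(=O)c2ccc(F)cc2)cc1` reaches only a limit of this assay, > 65500 nM. The step that the limit leaves unreadable from compound 1 to compound 2 cannot be read, because the limit of > 65500 nM in this assay, at which 1 of the 2 values shown sits, marks where compound 2 sits. Compound 3 `COc1ccc(-c2cc(=O)c3c(OC)cc(OC)cc3n2S(=O)(=O)Cc2ccccc2)cc1` differs from compound 1 by benzylsulfonyl in place of methyl on an aromatic nitrogen. Going by the values given here, the sole measured step touching this change is unreadable, so no direction can be drawn from it. Compound 3 is expected to stay near compound 1, an estimated step of a 1.0-fold lower number from compound 1 to compound 3 (0.02 log units; within the scatter). The estimate for compound 3 is 65000 nM, between 20000 nM and 200000 nM.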

Compound 3, half-maximal effective concentration: > 34400 nM
Compound 3 ended at the assay's limit; the forecaster's own chance of this, stated with the estimate: 50%; the middle value lies beyond the limit too.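

Compound 3 gives only a limit, so no new step can be read against compound 1 or compound 2. The compounds shown leave open whether either sulfonyl group truly changes the read-out compared with methyl.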